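Swapping an isopentyl chain for a methylated benzene ring

The source may report more compounds than this note shows. Statements on the series, on what has been measured and on what is new or still open speak of the compounds shown alone.

Of the compounds shown here, three sharing a common core have been measured in an assay on THP-1 cells for displacement of a labelled ligand from C-C chemokine receptor type 1 (Homo sapiens); on this read-out higher numbers stand for weaker inhibition and lower numbers for stronger inhibition. Compound 1 `CC(C)CCC(=O)N[C@@H](C(=O)N1CCC(c2ccc(Cl)cc2)CC1)C(C)C` gives 26 nM, the lowest number of the three. Compound 3 `CC[C@@H](NC(=O)c1ccccc1)C(=O)N1CCC(c2ccc(Cl)cc2)CC1` gives 121 nM, and compound 2 `CC(C)C(NS(=O)(=O)Cc1ccccc1)C(=O)N1CCC(c2ccc(Cl)cc2)CC1` gives 303 nM; both of these steps away from compound 1 lie beyond the usual scatter, so compound 1 is the strongest inhibitor on the numbers shown.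

Compound 4 `Cc1ccc(C(=O)N[C@@H](C(=O)N2CCC(c3ccc(Cl)cc3)CC2)C(C)C)cc1` has not yet been measured. It differs from compound 1 in one place: 4-methylphenyl in place of isopentyl on a carbonyl carbon. A flexible chain is thus replaced by a flat aromatic ring on the carbonyl carbon of the amide.

For the measured compounds named here, compound 3, the only other measured compound carrying an aromatic ring on its amide carbonyl, gives 121 nM, a weaker result than compound 1; although compound 3 also differs elsewhere, this hints that an aromatic amide may cost some potency. The step of a 2.7-fold higher number from compound 1 to compound 4 (0.43 log units; beyond the scatter) is therefore expected to be a modest loss, probably beyond the scatter but not large. Compound 4 is estimated at 70 nM, with a plausible range from 25 nM to 200 nM.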

Compound 4, half-maximal inhibitory concentration: 25 nM
The estimate for compound 4 lay 2.8-fold (0.45 log units) above the measured number, within the range that was stated.
By their numbers in this assay, from the lowest: compounds 4 and 1 (each within the scatter of the next); then compound 3; then compound 2.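

In this assay, the step of a 1.0-fold lower number from compound 1 to compound 4 (0.02 log units; within the scatter) lies within the scatter, so at this carbonyl carbon, in the setting of compound 1, isopentyl and 4-methylphenyl cannot be told apart, even though one has no ring and the other has a six-membered aromatic ring. The earlier compounds shown here could not show this: compound 2 and compound 3 each differ from compound 1 in more than one place, so neither isolates the group on this carbonyl carbon. Nothing available explains why the two groups give such similar numbers.

From the compounds shown here alone, it remains open how much variety this position accepts, for instance whether a cyclohexyl ring or a longer chain would match compound 1. A chain carrying an amine or a carboxylic acid would test whether a charged group is accepted here too.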